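This account rests on a few compounds, and the source may have more. Where it says the series, first, only, none or still open, it means among the compounds named here.

Measured compounds:
compound 1 `ClCc1ccc(Cn2cnc3c(Cl)ncnc32)cc1` gives 5490 nM
compound 2 `ClCc1ccc(Cn2cnc3nc(Cl)nc(Cl)c32)cc1` gives 3980 nM
compound 3 `ClCc1ccc(Cn2cnc3c(Cl)nc(Cl)nc32)cc1` gives 41700 nM

In a functional assay on RXF 393 cells (Homo sapiens) for cytotoxicity, read by sulforhodamine B assay, with a stated time of 48 h (on this read-out lower numbers stand for stronger inhibition of growth and higher numbers for weaker inhibition of growth), compound 2 holds the lowest of the three numbers. Its nearest neighbour is compound 1, whose value sits within the scatter of the measurement, so the two cannot be told apart. Compound 3 stands furthest away with a clearly higher number.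

The next compound to consider is compound 4 `ClCc1ccc(Cn2cnc3ncnc(Cl)c32)cc1`. Compared with compound 2 it shows (hydrogen in place of chloro on an aromatic carbon).

One measured step speaks to this change, but in the opposite direction: from compound 1 to compound 3 a chloro group enters at the same kind of position, and the number rises, a 7.6-fold higher number from compound 1 to compound 3 (0.88 log units; beyond the scatter). Read backwards, taking the chloro away would be expected to lower the number by a comparable amount. Compound 2 and compound 4, however, carry the benzyl group on a different ring nitrogen than compound 1 and compound 3, so the reverse reading is only a guide, not a guarantee.

On this basis the step from compound 2 to compound 4 in this assay is expected to be a 2.0-fold lower number from compound 2 to compound 4 (0.30 log units; within the scatter). The estimated value for compound 4 is 2000 nM, with a range from 600 nM to 7000 nM.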

Compound 4, concentration for total growth inhibition: 4160 nM
The estimate for compound 4 lay 2.1-fold (0.32 log units) below the measured number; low and high end bracket the measured number.
By their numbers in this assay, from the lowest: compounds 2, 4 and 1 (each within the scatter of the next); then compound 3.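

In this assay, hydrogen in place of chloro on the aromatic carbon between two ring nitrogen atoms gives a 1.0-fold higher number from compound 2 to compound 4 (0.02 log units; within the scatter), so the two compounds cannot be told apart and this chloro leaves no readable mark on growth inhibition on this core. Within the data shown here, until now the only view of this exchange came from the core of compound 1, where the chloro went with a clearly weaker result, and the new pair shows that this reading does not carry over to the other core, since the same change gives clearly different steps on the two: the same change on two cores in this assay, a 7.6-fold higher number (0.88 log units; beyond the scatter) from compound 1 to compound 3 and a 1.0-fold lower number (0.02 log units; within the scatter) from compound 4 to compound 2, 7.9-fold (0.90 log units) apart, beyond the scatter of two such steps. For these two pairs, then, what a chloro does at this kind of position cannot be judged from the position alone, and the core it sits on has to be taken into account.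

Only chloro and hydrogen appear on this carbon, which leaves open what an amine or a methoxy group there would give on either core. The compounds shown also leave open why the same exchange gives such different steps on the two cores.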